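Cinnamate esters: moving chlorine on the aryl ring

This account rests on a few compounds, and the source may have more. Where it says the series, first, only, none or still open, it means among the compounds named here.

Compound 2 `COc1cc(OC)c(OC)cc1/C=C/COC(=O)/C=C/c1ccc(Cl)cc1` is the point of departure. In a functional assay on the whole organism (strain Kunming) with Mus musculus as the target, with a stated time of 0.5 h, at a dose of 300 mg/kg by the intraperitoneal route (a lower number here means a stronger effect, a higher number a weaker effect of the compound at the dose given), compound 2 gives 50%. Compound 3 `COc1cc(OC)c(OC)cc1/C=C/COC(=O)/C=C/c1cc(OC)c(OC)c(OC)c1OC` gives 50% in this assay, level with compound 2 at the digits shown, and together these two are the lowest of the three numbers measured. Compound 1 `COc1cc(OC)c(OC)cc1/C=C/COC(=O)/C=C/c1ccc(OC)c(OC)c1OC` gives 75% in this assay, a higher number than compound 2, beyond the scatter.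

For the measured compounds named here, the only step measured so far within a single change is a number 25 percentage points lower from compound 1 to compound 3 (beyond the scatter); this is a substituent added to the aryl ring, not one moved on it, so it bears only loosely on the question here.

Compound 4 `COc1cc(OC)c(OC)cc1/C=C/COC(=O)/C=C/c1ccccc1Cl` differs from compound 2 in one place: 2-chlorophenyl in place of 4-chlorophenyl on a double-bonded chain carbon bound to a double-bonded chain carbon. Going by the values given here, no measured pair shows the effect of moving the chlorine on the ring, so there is no basis for expecting a step beyond the scatter in either direction.

Compound 4 is therefore expected to give 50% in this assay, within a range of 30% to 75%. Among the compounds with values here, the step implied, no change at the digits printed from compound 2 to compound 4 (within the scatter), is estimated to lie within the scatter, with the range kept wide because no measured step addresses this kind of change.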

Compound 4, a percentage reported as activity, at one dose (the size of the read-out at that dose, not a potency): 50%
For compound 4 middle estimate and measured number coincide at the digits printed; the measured number falls inside the stated range.
By their numbers in this assay, from the lowest: compounds 2, 3 and 4 (each within the scatter of the next); then compound 1.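

In this assay, for the compounds shown here, 2-chlorophenyl in place of 4-chlorophenyl on a double-bonded chain carbon bound to a double-bonded chain carbon gives no change at the digits printed from compound 2 to compound 4 (within the scatter), and this is the only pair that moves a substituent on the aryl ring rather than adding one. The two compounds have the same atoms joined differently, and at this single dose the read-out does not separate the two chlorine placements, whereas the added methoxy gave a number 25 percentage points lower from compound 1 to compound 3 (beyond the scatter). Nothing measured in the series accounts for this outcome.

As far as these compounds go, the result rests on one pair and one halogen, so it remains open whether a move on the ring would be equally silent for another group in place of chlorine, such as an amine, a carboxylic acid or a nitrile, or whether the same holds for a methoxy moved rather than added. From the compounds shown here alone, the read-out is also the size of the effect at one dose and one stated time rather than a potency, so a gap between the two chlorophenyl compounds at other doses or times also remains open.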